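The source may hold more compounds than are shown below. What is called first, only, known or untested is meant among the compounds shown, and "the series" means these compounds.

Measured so far in a functional assay on the whole organism with Mus musculus as the target; a lower number here means a smaller maximal response, a higher number a larger maximal response:

Compound 1, `C=CCn1c(=O)n(C2CCC(CO)C2)c2nc(N)nc(O)c21`: 0%
Compound 2, `C=CCn1c(=O)n(C2C=CC(CO)O2)c2nc(N)nc(O)c21`: 84%

Among the measured compounds shown here, compound 2 stands highest of the two numbers in this assay; its only neighbour is compound 1, and the step between them, a number 84 percentage points higher from compound 1 to compound 2 (beyond the scatter), is the sole measured step. That step exchanges the whole group on the aromatic nitrogen of the shared core and says nothing about the allyl chain.

Compound 3, `CCCn1c(=O)n(C2C=CC(CO)O2)c2nc(N)nc(O)c21`, is not yet measured. Relative to compound 2 the change is ethyl in place of vinyl on a saturated chain carbon bound to an aromatic nitrogen. For the measured compounds named here, no measured step touches this chain, so there is no direct precedent; the chain is small and sits away from the group that carried the large step. The working expectation is a step of a number 8 percentage points lower from compound 2 to compound 3 (within the scatter) from compound 2 to compound 3, that is, nothing beyond the scatter. Compound 3 is therefore expected to give about 76% in this assay. For compound 3 the estimated range runs from 45% to 95%.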

Compound 3, largest response reached (reported as maximal response), in percent of the reference or control that the assay uses: 84%
The estimate for compound 3 lay 8 percentage points below the measured number, and the stated range covers the measured number.
By their numbers in this assay, from the lowest: compound 1; then compounds 2 and 3 (each within the scatter of the next).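

Among the compounds shown here, the first measured change at this chain gives no change at the digits printed from compound 2 to compound 3 (within the scatter) in this assay, so with the group of compound 2 on the aromatic nitrogen, the double bond of the allyl chain is not needed to keep the maximal response. Among the compounds shown, only a number 84 percentage points higher from compound 1 to compound 2 (beyond the scatter) lies beyond the scatter, so the response follows the group on the aromatic nitrogen and not the switch from allyl to propyl. Nothing available explains why the switch leaves the response within the scatter.

On these data alone, it remains open whether propyl and allyl would also match with the group of compound 1 on the aromatic nitrogen. Also open, as far as these compounds go, is how far this tolerance extends, for example to a longer chain such as butyl, or to an amine or a carboxylic acid in place of propyl.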